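This account rests on a few compounds, and the source may have more. Where it says the series, first, only, none or still open, it means among the compounds named here.

Within the data shown here, compound 1 `Nc1ccccc1NC(=O)c1ccc(CSC(=S)N2CCN(Cc3ccccn3)CC2)cc1` carries a (pyridin-2-yl)methyl group on the ring amine nitrogen; in a functional assay on A-375 cells (Homo sapiens) for antiproliferative activity, read by CCK-8 assay, with a stated time of 72 h, tested at 2 uM (on this read-out higher numbers stand for a stronger effect at the one concentration tested and lower numbers for a weaker effect), compound 1 gives 20.7%, the higher of the two numbers so far. Compound 2 `Nc1ccccc1NC(=O)c1ccc(CSC(=S)N2CCN(C(c3ccccc3)c3ccccc3)CC2)cc1`, with a benzhydryl group at that position, gives 8.7% in this assay, a number beyond the scatter below compound 1. Compound 3 `Nc1ccccc1NC(=O)c1ccc(CSC(=S)N2CCN(c3ccc(Cl)cc3)CC2)cc1` has not been tested; it differs from compound 1 by 4-chlorophenyl in place of (pyridin-2-yl)methyl on an amine nitrogen in a ring. Among the measured compounds shown here, no measured pair shows this change, so the step is expected to be small, with the direction uncertain and possibly within the scatter: a number 5.7 percentage points lower from compound 1 to compound 3 (within the scatter). For compound 3 the expected value in this assay is 15%, within a range from 3% to 32%.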

Compound 3, a percentage reported as inhibition, at one concentration (the size of the read-out at that concentration, not a potency): 32.2%
Compound 3: middle estimate off by 17.2 percentage points, on the low side; measured number outside the range, above it.
By their numbers in this assay, from the lowest: compound 2; then compound 1; then compound 3.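

In this assay, 4-chlorophenyl in place of (pyridin-2-yl)methyl on the ring amine nitrogen gives a number 11.5 percentage points higher from compound 1 to compound 3 (beyond the scatter). The two groups have the same heavy-atom count, so that count alone does not set the read-out at this position. Nothing measured on these compounds accounts for the step.

Going by these compounds, the change swaps the ring type, adds chlorine and removes the methylene link together, so their separate contributions remain open. Phenyl or benzyl on the same nitrogen would help to separate them.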